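Oxime ethers on a shared core: benzyl replacement

The compounds below may be only part of what the source reports. "The series", "measured", "known", "first", "only" and "open" are said of these compounds alone.

Compound 1 `CC(C)(C)c1ccc(CO/N=C/c2c(-c3ccc4ccccc4c3)nc3occn23)cc1` carries a 4-(tert-butyl)phenyl on the saturated chain carbon bound to an oxygen on an unsaturated carbon. Among the compounds with values here, in an assay on HepG2 cells for agonist activity at nuclear receptor subfamily 1 group I member 3 (Homo sapiens), read by a luciferase reporter, with a stated time of 23 h (on this read-out higher numbers stand for an effect only at larger amounts of compound and lower numbers for an effect already at smaller amounts), compound 1 gives 7900 nM, the highest of the two numbers so far; compound 2 `Clc1ccc(-c2nc3occn3c2/C=N/OCc2ccc(Cl)c(Cl)c2)cc1` gives 410 nM, a gap beyond the scatter, though compound 2 differs from compound 1 in more than one place. Compound 3 `Clc1ccc(CO/N=C/c2c(-c3ccc4ccccc4c3)nc3occn23)c(Cl)c1` is not yet measured; its change from compound 1 is 2,4-dichlorophenyl in place of 4-(tert-butyl)phenyl on a saturated chain carbon bound to an oxygen on an unsaturated carbon. A decrease beyond the scatter is expected, a 5.3-fold lower number from compound 1 to compound 3 (0.72 log units; beyond the scatter), in this assay. Compound 3 is estimated at 1500 nM, with a range of 400 nM to 6000 nM.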

Compound 3, half-maximal effective concentration: 1500 nM
Compound 3: middle estimate and measured number agree at the digits printed; measured number inside the range.
By their numbers in this assay, from the lowest: compound 2; then compound 3; then compound 1.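

In this assay, 2,4-dichlorophenyl in place of 4-(tert-butyl)phenyl gives a 5.3-fold lower number from compound 1 to compound 3 (0.72 log units; beyond the scatter) and so shows that the group on the saturated chain carbon bound to an oxygen on an unsaturated carbon can alone move the number beyond the scatter. Compound 2 could not show this, as it differs from compound 1 in more than one place. No measurement at hand accounts for the step.

On these data alone, whether the step comes from removing 4-(tert-butyl)phenyl or from the two chlorines remains open, and a single chlorine on the phenyl would help separate these. As far as these compounds go, how an amine or a carboxylic acid on the phenyl would behave at this position is also open.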